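The source may report more compounds than this note shows. Statements on the series, on what has been measured and on what is new or still open speak of the compounds shown alone.

Among the measured compounds shown here, compound 2 `CCCCCNC(=O)CC1CCc2cc(OC)c(OC)cc21` gives 40.6% in a functional assay on the whole organism (strain Wistar) for inhibition, with Rattus norvegicus as the target, read by paw edema, with stated times of 60 min and 4 h, at a dose of 100 mg/kg by the oral route (a lower number here means less inhibition, a higher number more inhibition at the dose given (going by the name of the read-out)), the higher of the two numbers so far. Compound 1 `CCNC(=O)CC1CCc2cc(OC)c(OC)cc21` gives 26.6% there, and the step of a number 14 percentage points higher from compound 1 to compound 2 (beyond the scatter) shows that lengthening the chain raised the read-out. Compound 3 `COc1cc2c(cc1OC)C(CC(=O)NCc1ccccc1)CC2` differs from compound 2 by phenyl in place of butyl on a saturated chain carbon bound to an amide-type nitrogen. For the measured compounds named here, no measured step trades a chain for a ring, so the only bearing evidence is that step from compound 1 to compound 2, whose direction suggests a larger group here does not hurt. A step of a number 4.4 percentage points higher from compound 2 to compound 3 (within the scatter) within the scatter is therefore expected. For compound 3 the estimate is 45%, between 30% and 60%.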

Compound 3, a percentage reported as inhibition, in the whole organism at one dose (the size of the read-out at that dose, not a potency): 18.8%
Estimate against measurement, compound 3: 26.2 percentage points above; the whole stated range lies above it.
By their numbers in this assay, from the lowest: compounds 3 and 1 (each within the scatter of the next); then compound 2.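

In this assay, replacing butyl with phenyl on a saturated chain carbon bound to an amide-type nitrogen gives a number 21.8 percentage points lower from compound 2 to compound 3 (beyond the scatter) and removes the gain that the pentyl chain had shown. Replacing methyl with phenyl at the same place gives a number 7.8 percentage points lower from compound 1 to compound 3 (within the scatter) and leaves the read-out within the scatter, so among these compounds, more heavy atoms on the amide nitrogen's chain do not by themselves raise it. Nothing available explains why the benzyl group differs from the pentyl chain. As far as these compounds go, it remains open whether a chain longer than pentyl would raise the read-out further. Also open, from the compounds shown here alone, is how a phenethyl group, or a benzyl group carrying a methoxy group or a carboxylic acid, would compare.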